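The source may hold more compounds than are shown below. What is called first, only, known or untested is meant among the compounds shown, and "the series" means these compounds.

Notes on the aryl variation of the shared core. In a functional assay on MCF7 cells (Homo sapiens) for inhibition, read by sulforhodamine B assay, with a stated time of 48 h (a higher number here means a weaker inhibitor of growth, a lower number a stronger inhibitor of growth), compound 1 `COC(=O)c1sc2cc(-c3cnc4ccccc4c3)cnc2c1N` gives 9800 nM. Compound 2 `COC(=O)c1sc2cc(-c3ccc(C(C)=O)cc3)cnc2c1N` reaches only the limit of this assay and gives > 150000 nM, which is a limit of the measurement and not a number. Compound 2 therefore stands at the weak end of the numbers shown, on the line (the limit of > 150000 nM in this assay, at which 1 of the 2 values shown sits), with no finite value to set against compound 1. Compound 3 `COC(=O)c1sc2cc(-c3ccc(OC)cc3)cnc2c1N` changes the same place: methoxy in place of acetyl on an aromatic carbon. Going by the values given here, no step between measured compounds covers this change, and nothing measured relates the methoxy group to the acetyl group. The step from compound 2 to compound 3 is expected to be an at least 1.2-fold lower number from compound 2 to compound 3 (0.09 log units; that floor lies within the scatter), with no direction beyond the scatter. Compound 3 is estimated at 120000 nM, in a range from 25000 nM to 400000 nM, with a fair chance that this assay again reports only a limit.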

Compound 3, concentration for 50% growth inhibition: > 150000 nM
Compound 3: no number, only a limit; the forecaster's own chance of this, stated with the estimate: 55%; middle value at least 1.2-fold (0.09 log units) from the limit.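

Going by these compounds alone, compound 2 and compound 3 both reach only the limit of this assay, so no step between them can be read: the limit of > 150000 nM in this assay, at which 2 of the 3 values shown sit. The compounds shown leave open whether methoxy and acetyl differ at all in this growth inhibition read-out.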